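This account rests on a few compounds, and the source may have more. Where it says the series, first, only, none or still open, it means among the compounds named here.

Measured compounds in a functional assay on the whole organism (strain Wistar) for inhibition, with Rattus norvegicus as the target, read by paw edema, with stated times of 60 min and 6 h, at a dose of 100 mg/kg by the oral route; on this read-out lower numbers stand for less inhibition and higher numbers for more inhibition at the one dose given (going by the name of the read-out):
compound 1 `CCN(CC)C(=O)CC1CCc2cc(OC)c(OC)cc21` gives 31.5%
compound 2 `COc1cc2c(cc1OC)C(CC(=O)N1CCCC1)CC2` gives 22.2%

Going by the values given here, compound 2 stands within the usual scatter of compound 1, the only other measured compound; the step of a number 9.3 percentage points lower from compound 1 to compound 2 (within the scatter) is an exchange of the amine on the carbonyl carbon that leaves the read-out essentially where it was. Compound 3 `COc1cc2c(cc1OC)C(CC(=O)N1CCOCC1)CC2` is the next member of the series and has not yet been measured in this assay. Its change from compound 2 is morpholin-4-yl in place of pyrrolidin-1-yl on a carbonyl carbon. Among the compounds with values here, the one measured step bears on it directly, since it also exchanges the amine on the same carbonyl carbon: a number 9.3 percentage points lower from compound 1 to compound 2 (within the scatter) stayed within the scatter. Within the data shown here, no step involving a morpholin-4-yl group is known, so the size of the new step rests on that single exchange. On this basis no step beyond the scatter is expected for a number 2.2 percentage points lower from compound 2 to compound 3 (within the scatter), with a flat or somewhat lower read-out the most likely outcome. Compound 3 is therefore expected to give about 20% in this assay, with a plausible range from 8% to 34%.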

Compound 3, a percentage reported as inhibition, in the whole organism at one dose (the size of the read-out at that dose, not a potency): 14.8%
Compound 3: the middle estimate sits 5.2 percentage points above what was measured, and the stated range covers the measured number.
By their numbers in this assay, from the lowest: compounds 3, 2 and 1 (each within the scatter of the next, the first and the last beyond it).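

In this assay, the change at the carbonyl carbon from pyrrolidin-1-yl to morpholin-4-yl gives a number 7.4 percentage points lower from compound 2 to compound 3 (within the scatter), so a second amine exchange at this place stays inside the usual scatter, this time with a six-membered ring carrying a further oxygen. Going by these compounds alone, the place is nevertheless not indifferent to the amine across the whole set: a number 16.7 percentage points lower from compound 1 to compound 3 (beyond the scatter), the first step here to pass the scatter, although a modest one, separates diethylamino from morpholin-4-yl, while pyrrolidin-1-yl cannot be told apart from either. Nothing available accounts for this separation, and the result rests on these read-outs alone.

Going by these compounds, it remains open whether piperidin-1-yl, a six-membered ring without the oxygen, would read with pyrrolidin-1-yl or with morpholin-4-yl, and whether a longer open-chain amine such as dipropylamino would extend the gap from morpholin-4-yl seen with diethylamino. All the compounds shown also keep an amide on the same saturated chain carbon and the same methoxy groups on the shared core, so the effect of a carboxylic acid in place of the amide, or of a longer chain, is also unresolved.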